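The source may hold more compounds than are shown below. What is called first, only, known or untested is meant among the compounds shown, and "the series" means these compounds.

Measured compounds:
compound 1 `CCO/C=N/c1c(C#N)ncn1Cc1ccccc1`, 9.8% in an assay on CHO cells for displacement of a labelled ligand from adenosine receptor A1 (Homo sapiens), read by scintillation counting, with a stated time of 60 min, tested at 10 uM; on this read-out lower numbers stand for less inhibition and higher numbers for more inhibition at the one concentration tested (going by the name of the read-out)
compound 2 `OC1=NCC2C(C=NN2Cc2ccccc2)C(c2ccc(Br)cc2)S1`, 18.8% in this assay

Of the two numbers measured in this assay, compound 1 gives 9.8% and compound 2 gives 18.8%; the two lie within the usual scatter of each other, so no order between them can be claimed. Compound 3 `CCO/C(C)=N/c1c(C#N)ncn1Cc1ccccc1` is the unmeasured partner of compound 1: the change is a group of 6 heavy atoms (4 carbon, 1 nitrogen, 1 oxygen; no ring) in place of a group of 5 heavy atoms (3 carbon, 1 nitrogen, 1 oxygen; no ring), on an aromatic carbon. Going by the values given here, no measured pair shows a comparable step. The expected step is a number 2.2 percentage points higher from compound 1 to compound 3 (within the scatter), which is none beyond the scatter. In this assay compound 3 is expected to give 12%, estimated between 0% and 28%.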

Compound 3, a percentage reported as inhibition, at one concentration (the size of the read-out at that concentration, not a potency): 1.2%
For compound 3 the middle estimate is 10.8 percentage points above the measured one, and the stated range covers the measured number.
By their numbers in this assay, from the lowest: compounds 3, 1 and 2 (each within the scatter of the next, the first and the last beyond it).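

In this assay, replacing the group of 5 heavy atoms with the group of 6 heavy atoms on this aromatic carbon gives a number 8.6 percentage points lower from compound 1 to compound 3 (within the scatter). This one-place step therefore shows no effect of this change that can be separated from the scatter at the one concentration tested. No available evidence bears on this result. The compounds shown leave open whether an amine or a longer chain on this aromatic carbon would shift the number beyond the scatter.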